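Adding a second hydroxy to the fused core of compound 3

A few compounds are considered here, and "the series" means these few. Any claim that something is new, unique, unknown or untested is made for them only; others in the source may bear on it.

Measured compounds:
compound 1, `O=c1cc(/C=C/c2ccc(O)cc2)oc2cc(O)ccc12`, 1650 nM
compound 2, `O=c1cc(/C=C/c2ccc(O)c(O)c2)oc2cc(O)cc(O)c12`, 630 nM
compound 3, `O=c1cc(/C=C/c2ccc(O)cc2)oc2cccc(O)c12`, 980 nM

All three were tested in a functional assay, in the presence of a further agent that is not named here; on this read-out lower numbers stand for stronger inhibition and higher numbers for weaker inhibition. Compound 3 gives the second highest of the three numbers. Its nearest neighbour is compound 2, whose number is lower but within the scatter of repeat measurements; its furthest neighbour is compound 1, whose number is higher but also within the scatter. Going by the values given here, on these three values, then, no compound is separated from another beyond what repeat runs of this assay would show.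

Compound 4, `O=c1cc(/C=C/c2ccc(O)cc2)oc2cc(O)cc(O)c12`, has not yet been measured. It differs from compound 3 in one place: hydroxy in place of hydrogen on an aromatic carbon. The resulting core carries two hydroxy groups in the arrangement also found in compound 2, while the styryl part stays as in compound 3 and compound 1. Among the compounds with values here, since no step between two measured compounds differing in one place is available, and the three measured values lie within the scatter of one another, a step from compound 3 to compound 4 is expected to stay within the scatter, leaning slightly toward a lower number. The step from compound 3 to compound 4 is estimated as a 1.2-fold lower number from compound 3 to compound 4 (0.09 log units; within the scatter). For compound 4 in this assay the expected value is 800 nM, within 350 nM to 1800 nM.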

Compound 4, half-maximal inhibitory concentration: 1210 nM
Estimate against measurement, compound 4: 1.5-fold (0.18 log units) below, within the range that was stated.
By their numbers in this assay, from the lowest: compounds 2, 3, 4 and 1 (each within the scatter of the next, the first and the last beyond it).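

In this assay, the hydroxy that turns compound 3 into compound 4 gives a 1.2-fold higher number from compound 3 to compound 4 (0.09 log units; within the scatter), and the hydroxy that turns compound 1 into compound 4, placed on a different carbon of the same ring, gives a 1.4-fold lower number from compound 1 to compound 4 (0.13 log units; within the scatter), so neither single addition to the core separates from the scatter. The third comparison, which concerns the styryl part rather than the core, is a 1.9-fold higher number from compound 2 to compound 4 (0.28 log units; within the scatter), also within the scatter, so these first one-place comparisons show that compound 4 stands apart from none of its three neighbours and that this position accepts a hydroxy without a readable change on this read-out. Nothing measured here speaks to why the numbers stay so close.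

The compounds shown leave open whether a methoxy group, a fluorine atom or an amine on this aromatic carbon would move the number beyond the scatter. They also leave open which single change, if any, accounts for the gap beyond the scatter between compound 2 and compound 1, which differ in more than one place.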